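This account rests on a few compounds, and the source may have more. Where it says the series, first, only, none or still open, it means among the compounds named here.

Compound 1 `COC(=O)C1=C(C)N=C(SC)NC1c1cccc([N+](=O)[O-])c1` gives 2500 nM in a functional assay (aorta) for inhibition, with Oryctolagus cuniculus as the target; on this read-out lower numbers stand for stronger inhibition and higher numbers for weaker inhibition. Compound 2 `COC(=O)C1=C(C)N=C(SC)NC1c1cc([N+](=O)[O-])ccc1SC` gives 20000 nM in this assay, so that the step of an 8.0-fold higher number from compound 1 to compound 2 (0.90 log units; beyond the scatter) goes with the change (methylsulfanyl in place of hydrogen on an aromatic carbon). Compound 3 `CSC1=NC(c2cccc([N+](=O)[O-])c2)C2=C(O)OCC2=N1` gives > 30000 nM in this assay, which is a limit of the assay and not a number. That value is one that sits at the limit of > 30000 nM in this assay, at which 1 of the 3 values shown sits. The difference between the core of compound 1 and the core of compound 3 is not broken down here. Compound 4 `CSC1=NC(c2cccc([N+](=O)[O-])c2SC)C2=C(O)OCC2=N1` differs from compound 3 by methylsulfanyl in place of hydrogen on an aromatic carbon, the same kind of change as from compound 1 to compound 2, though here the place is ortho to a nitro group rather than para to a nitro group. Resting on the earlier step of an 8.0-fold higher number from compound 1 to compound 2 (0.90 log units; beyond the scatter), compound 4 is expected to make a step that the limit leaves unreadable from compound 3 to compound 4. Compound 4 is therefore estimated at 80000 nM, most likely again only a limit.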

Compound 4, half-maximal inhibitory concentration: > 30000 nM
Compound 4: a limit, no number; the forecaster's own chance of this, stated with the estimate: 85%; the middle value does not contradict the limit.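

In this assay, compound 3 and compound 4 both sit at a limit of the assay, so no step between them can be read: the limit of > 30000 nM in this assay, at which 2 of the 4 values shown sit.

The compounds shown leave open whether methylsulfanyl in place of hydrogen on an aromatic carbon changes the read-out at all on the core of compound 3.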